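Chain shortening and cytotoxicity: working notes on four compounds

The compounds below may be only part of what the source reports. "The series", "measured", "known", "first", "only" and "open" are said of these compounds alone.

Measured so far:
compound 1, `CC(C)[S+]([O-])CCCCN=C=S`, 2050 nM
compound 2, `[O-][S+](CCCCN=C=S)Cc1ccccc1`, 2850 nM
compound 3, `[O-][S+](CCCN=C=S)Cc1ccccc1`, 9840 nM

All three values come from a functional assay on HepG2 cells (Homo sapiens) for cytotoxicity, read by MTT assay, with a stated time of 72 h; a higher number here means a weaker inhibitor, a lower number a stronger inhibitor. Compound 1 and compound 2 differ in more than one place; the difference between the two cores is not broken down here. In this assay compound 1 and compound 2 give values within the scatter of each other, so no order between them is claimed. From compound 2 to compound 3 the change is a group of 3 heavy atoms (1 carbon, 1 nitrogen, 1 sulfur; no ring) in place of a group of 4 heavy atoms (2 carbon, 1 nitrogen, 1 sulfur; no ring), on a saturated chain carbon, three bonds along the chain from a sulfur, and it gave a 3.5-fold higher number from compound 2 to compound 3 (0.54 log units; beyond the scatter).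

Compound 4, `CC(C)[S+]([O-])CCCN=C=S`, is still to be measured in this assay. From compound 1 to compound 4 the change is a group of 3 heavy atoms (1 carbon, 1 nitrogen, 1 sulfur; no ring) in place of a group of 4 heavy atoms (2 carbon, 1 nitrogen, 1 sulfur; no ring), on a saturated chain carbon, three bonds along the chain from a sulfur. The place is the same in both pairs, so this is the same change made on the other core, with one measured instance to go by.

The step from compound 1 to compound 4 is expected to be a 3.5-fold higher number from compound 1 to compound 4 (0.55 log units; beyond the scatter), because the same change gave a 3.5-fold higher number from compound 2 to compound 3 (0.54 log units; beyond the scatter). Compound 4 is expected to give 7200 nM, with a likely range from 3500 nM to 15000 nM.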

Compound 4, half-maximal inhibitory concentration: 7140 nM
Beside the measured number, compound 4's estimate is 1.0-fold (0.00 log units) above it, and the stated range covers the measured number.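

In this assay, the group of 3 heavy atoms in place of the group of 4 heavy atoms gave a 3.5-fold higher number from compound 1 to compound 4 (0.54 log units; beyond the scatter). The change therefore carries from the core of compound 2 to the core of compound 1 with its direction and size kept, and the two steps do not differ: the same change on two cores in this assay, a 3.5-fold higher number (0.54 log units; beyond the scatter) from compound 2 to compound 3 and a 3.5-fold higher number (0.54 log units; beyond the scatter) from compound 1 to compound 4, 1.0-fold (0.00 log units) apart, within the scatter of two such steps. This is one change on two cores in a single assay, so it does not show that the step would hold on any other core or in any other assay, nor does it say why the number rises when the chain is shorter.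

The compounds shown leave open what a longer chain would do on either core, and whether the step would keep its size there. They also leave open whether a nitrile or an amine in place of the whole group would keep the values seen in this series.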